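Hydrazone aryl replacement and adenosine receptor binding

This account rests on a few compounds, and the source may have more. Where it says the series, first, only, none or still open, it means among the compounds named here.

Measured compounds:
compound 1, `Nc1nc(N/N=C/c2ccc(OCc3ccc(F)cc3)cc2)nc2c1ncn2[C@@H]1O[C@H](CO)[C@@H](O)[C@H]1O`: 70 nM
compound 2, `Nc1nc(N/N=C/c2cccnc2Cl)nc2c1ncn2[C@@H]1O[C@H](CO)[C@@H](O)[C@H]1O`: 4.6 nM
compound 3, `Nc1nc(N/N=C/c2ccc(N(c3ccccc3)c3ccccc3)cc2)nc2c1ncn2[C@@H]1O[C@H](CO)[C@@H](O)[C@H]1O`: > 10000 nM

In an assay on CHO-K1 cells for displacement of a labelled ligand from adenosine receptor A1 (Homo sapiens), read by scintillation counting, with a stated time of 60 min (a lower number here means a stronger inhibitor, a higher number a weaker inhibitor), compound 2 gives 4.6 nM, the lowest of the two numbers shown, and compound 1 gives 70 nM, a gap beyond the scatter. For compound 3 the assay reports only a limit, (the limit of > 10000 nM in this assay, at which 1 of the 3 values shown sits), not a number. Compound 4, `N#Cc1ccc(/C=N/Nc2nc(N)c3ncn([C@@H]4O[C@H](CO)[C@@H](O)[C@H]4O)c3n2)cc1`, differs from compound 2 in one place: 4-cyanophenyl in place of 2-chloropyridin-3-yl on a carbon with a double bond to nitrogen. Within the data shown here, no measured pair shows this exact change, so the step from compound 2 to compound 4 is expected to be a modest loss, a 3.3-fold higher number from compound 2 to compound 4 (0.51 log units; beyond the scatter), of a size around the edge of the scatter. Compound 4 is therefore expected to give 15 nM, with a range from 4 nM to 60 nM.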

Compound 4, inhibition constant: 4.1 nM
Compound 4: middle estimate off by 3.7-fold (0.56 log units), on the high side; the measured number falls inside the stated range.
By their numbers in this assay, from the lowest: compounds 4 and 2 (each within the scatter of the next); then compound 1. At a limit, above all of these: compound 3.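

In this assay, the carbon with a double bond to nitrogen carries 4-cyanophenyl as readily as 2-chloropyridin-3-yl (a 1.1-fold lower number from compound 2 to compound 4 (0.05 log units; within the scatter)), so neither the ring nitrogen nor the chlorine of 2-chloropyridin-3-yl is needed for a low number here. On the aromatic carbon, cyano in place of (4-fluorobenzyl)oxy brings a large gain (a 17-fold lower number from compound 1 to compound 4 (1.23 log units; beyond the scatter)), which no earlier pair could show, and nothing given here explains either step. Still open, as far as these compounds go, is whether an amine or a carboxylic acid in place of cyano on that aromatic carbon would keep the number this low.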